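Swapping the Substituted Phenyl for Fluorophenyl on the Carbonyl

The compounds below may be only part of what the source reports. "The series", "measured", "known", "first", "only" and "open" are said of these compounds alone.

Measured compounds:
Compound 1 `COc1ccc(C(=O)N2CCC(=CC(=O)N[C@@H]3CCN(Cc4ccc5cc(F)ccc5c4)C3)CC2)c(O)c1`: 232 mL/min/kg
Compound 2 `O=C(C=C1CCN(C(=O)c2cccc(F)c2)CC1)N[C@@H]1CCN(Cc2ccc3cc(F)ccc3c2)C1`: 459 mL/min/kg

Compound 1 and compound 2 share a core and differ only in the aryl group attached to the carbonyl carbon. In an in vitro ADME assay on microsomes from liver (Homo sapiens) for metabolic stability (a higher number here means faster removal of the compound, a lower number slower removal), compound 1 gives 232 mL/min/kg, while compound 2 gives 459 mL/min/kg. Within the data shown here, compound 1 is thus one of only two measured compounds, and its sole neighbour is compound 2, reached by a 2.0-fold higher number from compound 1 to compound 2 (0.30 log units; within the scatter) — a step that sits inside the usual scatter, so the two numbers cannot be told apart with confidence.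

Compound 3 `O=C(C=C1CCN(C(=O)c2ccc(F)cc2)CC1)N[C@@H]1CCN(Cc2ccc3cc(F)ccc3c2)C1` has not yet been measured in this assay. It differs from compound 1 as follows: 4-fluorophenyl in place of 2-hydroxy-4-methoxyphenyl on a carbonyl carbon. Among the measured compounds shown here, the one measured step that bears on this change is the one from compound 1 to compound 2, where a fluorophenyl likewise replaced the 2-hydroxy-4-methoxyphenyl on the carbonyl carbon and the clearance moved by a 2.0-fold higher number from compound 1 to compound 2 (0.30 log units; within the scatter).

Compound 3 is therefore expected to show a step of about a 1.7-fold higher number from compound 1 to compound 3 (0.24 log units; within the scatter), upward but of a size that may not exceed the scatter. For compound 3 the estimated clearance is 400 mL/min/kg, with a range from 200 mL/min/kg to 800 mL/min/kg.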

Compound 3, clearance: 237 mL/min/kg
The estimate for compound 3 lay 1.7-fold (0.23 log units) above the measured number; the range from low to high includes it.
By their numbers in this assay, from the lowest: compounds 1, 3 and 2 (each within the scatter of the next).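

With compound 3 the position on the carbonyl carbon now has three aryl groups to compare, and this assay separates none of them: 4-fluorophenyl in place of 2-hydroxy-4-methoxyphenyl gives a step (a 1.0-fold higher number from compound 1 to compound 3 (0.01 log units; within the scatter)) that lies within the scatter, and 4-fluorophenyl in place of 3-fluorophenyl gives another (a 1.9-fold lower number from compound 2 to compound 3 (0.29 log units; within the scatter)) that does as well. The earlier pair offered one fluorophenyl against the 2-hydroxy-4-methoxyphenyl group, whereas these three compounds show that neither taking away that group's hydroxy and methoxy substituents nor changing 3-fluorophenyl to 4-fluorophenyl yields a difference this assay can resolve, so within this set the clearance cannot be tied to the choice of aryl group. Nothing available explains why these numbers fall as they do.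

From the compounds shown here alone, all three compounds keep a six-membered aromatic ring of carbon only on the carbonyl carbon, so it remains open whether a pyridine ring, or a saturated ring such as cyclohexyl, would give a step beyond the scatter. Going by these compounds, it is equally open whether an amine or a carboxylic acid on the phenyl ring would separate from these three, or whether changes elsewhere on the shared core matter more than this position does.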